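This account rests on a few compounds, and the source may have more. Where it says the series, first, only, none or still open, it means among the compounds named here.

Measured so far in a physicochemical assay for lipophilicity; on this read-out higher numbers stand for higher lipophilicity and lower numbers for lower lipophilicity:
- compound 1 `CC(C)c1cc(Cl)cc(C(C)C)c1O`: 5.34
- compound 2 `CC(C)c1cc(Br)cc(C(C)C)c1O`: 5.49

Only these two numbers exist, and they cannot be told apart. Among the measured compounds shown here, the one measured step is a number 0.15 log units higher from compound 1 to compound 2 (within the scatter), so compound 2 stands level with the only other measured compound.

The next compound, compound 3 `CC(C)c1cc(I)cc(C(C)C)c1O`, has not yet been measured. It differs from compound 2 as follows: iodo in place of bromo on an aromatic carbon. In words, this is iodo in place of bromo on an aromatic carbon, para to a hydroxy group.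

For the measured compounds named here, only one measured step bears on this change: bromo in place of chloro on an aromatic carbon, a number 0.15 log units higher from compound 1 to compound 2 (within the scatter). One small step is thin evidence. Still, a step of similar size is expected in this assay, upward and not clearly beyond the scatter. The estimated step is a number 0.18 log units higher from compound 2 to compound 3 (within the scatter). The expected value for compound 3 is 5.67, with an estimated range from 5.45 to 5.95.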

Compound 3, partition coefficient: 5.75
Beside the measured number, compound 3's estimate is 0.08 log units below it; low and high end bracket the measured number.
By their numbers in this assay, from the lowest: compounds 1, 2 and 3 (each within the scatter of the next, the first and the last beyond it).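

Iodo in place of bromo at this position, para to a hydroxy group, gives a number 0.26 log units higher from compound 2 to compound 3 (within the scatter), so this single exchange cannot be told apart on this assay. Iodo in place of chloro, however, gives a number 0.41 log units higher from compound 1 to compound 3 (beyond the scatter), the first gap in this short series that stands clear of the scatter: two exchanges too small to read alone span a modest difference that can be read. Nothing measured here explains this difference.

The compounds shown cover three halogens at this one position, with the hydroxy group and both isopropyl groups unchanged, so fluoro, a methyl or an amine at this place remains open. On these data alone, whether the same exchange would give a similar step on a core without the hydroxy group also stays open.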